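A few compounds are considered here, and "the series" means these few. Any claim that something is new, unique, unknown or untested is made for them only; others in the source may bear on it.

Measured compounds in a functional assay on HepG2 cells (Homo sapiens) for antiproliferative activity, read by MTT assay, with a stated time of 72 h; a higher number here means a weaker inhibitor, a lower number a stronger inhibitor:

Compound 1 `Cc1nn(C)c(Oc2ccc(F)c(F)c2)c1/C=N\CCCCCCOc1cc2oc(=O)cc(C)c2cc1Cl` gives a value of > 25000 nM, which is a limit of this assay rather than a number.
Compound 2 `Cc1nn(C)c(Oc2ccccc2Br)c1/C=N\CCCCCCOc1cc2oc(=O)cc(C)c2cc1Cl` gives 24200 nM.
Compound 3 `Cc1nn(C)c(Oc2ccc(Br)cc2)c1/C=N\CCCCCCOc1cc2oc(=O)cc(C)c2cc1Cl` gives 4630 nM.

Compound 3 holds the lowest number among the three; its nearest neighbour is compound 2, separated by a 5.2-fold lower number from compound 2 to compound 3 (0.72 log units; beyond the scatter), and compound 1 sits only at a limit (the limit of > 25000 nM in this assay, at which 1 of the 3 values shown sits). The step from compound 1 is an at least 5.3-fold lower number from compound 1 to compound 3 (0.73 log units; beyond the scatter), while between compound 1 and compound 2 the change is an at least 1.0-fold lower number from compound 1 to compound 2 (0.01 log units; that floor lies within the scatter).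

Compound 4 `Cc1ccc(Oc2c(/C=N\CCCCCCOc3cc4oc(=O)cc(C)c4cc3Cl)c(C)nn2C)cc1` differs from compound 3 by methyl in place of bromo on an aromatic carbon. The measured steps that touch the same aryloxy ring are a 5.2-fold lower number from compound 2 to compound 3 (0.72 log units; beyond the scatter) and an at least 5.3-fold lower number from compound 1 to compound 3 (0.73 log units; beyond the scatter); both vary the position or identity of halogens on that ring and none exchanges bromo for methyl, so they bear only indirectly on this change. They show that this ring tolerates a single substituent para to the large group best, and compound 4 keeps that arrangement. The expected step in this assay is therefore small, a 1.5-fold higher number from compound 3 to compound 4 (0.18 log units; within the scatter), with the direction uncertain. For compound 4 the estimated value in this assay is 7000 nM, within a range of 2500 nM to 20000 nM.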

Compound 4, half-maximal inhibitory concentration: 20700 nM
Estimate against measurement, compound 4: 3.0-fold (0.47 log units) below; the measured number lies above the stated range.
By their numbers in this assay, from the lowest: compound 3; then compounds 4 and 2 (each within the scatter of the next). At a limit, above all of these: compound 1.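

Bromo to methyl at this position is not a neutral exchange: a 4.5-fold higher number from compound 3 to compound 4 (0.65 log units; beyond the scatter) in this assay. The earlier steps shown here changed the position or identity of halogens, whereas here a single substituent stays para to a large group and only its identity changes, so that arrangement alone does not carry the lower number of compound 3. The 4-methylphenyl and 2-bromophenyl ethers cannot be told apart, a 1.2-fold lower number from compound 2 to compound 4 (0.07 log units; within the scatter), and compound 1 is a limit and not a number, so its comparison gives only a floor, an at least 1.2-fold lower number from compound 1 to compound 4 (0.08 log units; that floor lies within the scatter), with nothing to separate the 4-methylphenyl compound from the 3,4-difluorophenyl compound: the limit of > 25000 nM in this assay, at which 1 of the 4 values shown sits.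

Whether the lower number belongs to bromo alone remains open, as no chloro, iodo, trifluoromethyl, methoxy or amine group is shown at this position. The linking chain and the shared core are also constant across these compounds, so whether the bromo to methyl step holds with a shorter or longer chain is unresolved.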